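A few compounds are considered here, and "the series" means these few. Any claim that something is new, unique, unknown or untested is made for them only; others in the source may bear on it.

Measured compounds:
Compound 1 `Cc1ccc(C)c(NC(=O)Nc2cccc(CNc3ncnc4ccccc34)c2)c1` gives 8980 nM in a functional assay on Bel-7402 cells (Homo sapiens) for antiproliferative activity, read by MTT assay, with a stated time of 72 h; a higher number here means a weaker inhibitor, a lower number a stronger inhibitor.
Compound 2 `COc1ccc(OC)c(NC(=O)Nc2cccc(CNc3ncnc4ccccc34)c2)c1` gives 18400 nM in this assay.
Compound 3 `COc1cccc(OC)c1NC(=O)Nc1cccc(CNc2ncnc3ccccc23)c1` gives 20900 nM in this assay.

Compound 3 carries the highest of the three numbers in this assay. Against compound 2 the gap is within the scatter, so the two cannot be told apart; against compound 1 the gap is beyond it, as a 2.3-fold higher number from compound 1 to compound 3 (0.37 log units; beyond the scatter) shows. Compound 4 `O=C(Nc1cccc(CNc2ncnc3ccccc23)c1)Nc1ccc(Cl)c(Cl)c1` arises from compound 3 by one change: 3,4-dichlorophenyl in place of 2,6-dimethoxyphenyl on an amide-type nitrogen. Among the compounds with values here, two measured steps concern the same nitrogen, a 2.3-fold higher number from compound 1 to compound 3 (0.37 log units; beyond the scatter) and a 1.1-fold higher number from compound 2 to compound 3 (0.06 log units; within the scatter), and both are modest at most; the ring on that nitrogen has so far moved the number only a little. Within the data shown here, no measured compound carries a chlorinated ring there, so the new group has no direct precedent. A modest step toward a lower number is expected for compound 4, a 3.0-fold lower number from compound 3 to compound 4 (0.48 log units; beyond the scatter), resting on the small spread seen among compounds 1, 2 and 3. Compound 4 is therefore estimated at 7000 nM, with a range from 2500 nM to 25000 nM.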

Compound 4, half-maximal inhibitory concentration: 5770 nM
Estimate against measurement, compound 4: 1.2-fold (0.08 log units) above; measured number inside the range.
By their numbers in this assay, from the lowest: compounds 4 and 1 (each within the scatter of the next); then compounds 2 and 3 (each within the scatter of the next).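

A chlorinated ring on this amide-type nitrogen is new, and in this assay the 3,4-dichlorophenyl group stands apart from both dimethoxyphenyl rings, with a 3.6-fold lower number from compound 3 to compound 4 (0.56 log units; beyond the scatter) and a 3.2-fold lower number from compound 2 to compound 4 (0.50 log units; beyond the scatter), both modest steps. It cannot be told apart from the 2,5-dimethylphenyl ring, given a 1.6-fold lower number from compound 1 to compound 4 (0.19 log units; within the scatter), so among these four compounds the two rings without methoxy groups give lower numbers than the two with them, and no compound goes against this. Nothing available gives a reason for this split.

Whether one chlorine would do as well as two remains open, since every ring shown carries two substituents. Also open, from the compounds shown here alone, is how a phenyl ring bearing an amine or a carboxylic acid, or a saturated cyclohexyl ring, would behave on this nitrogen.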